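The source may report more compounds than this note shows. Statements on the series, on what has been measured and on what is new or still open speak of the compounds shown alone.

Of the compounds shown here, three of one shared core have been measured in a functional assay (trachea) with Cavia porcellus as the target; on this read-out higher numbers stand for weaker inhibition and lower numbers for stronger inhibition. Compound 1 `CC(C)n1nc(-c2cccnc2)c2ccccc2c1=O` gives 3090 nM. Compound 2 `O=c1c2ccccc2c(-c2cccnc2)nn1Cc1cccc(Cl)c1` gives 4170 nM, and compound 3 `O=c1c2ccccc2c(-c2cccnc2)nn1S(=O)(=O)c1ccccc1` gives 14800 nM. Among these, compound 2 has the second highest number of the three: its nearest neighbour is compound 1, whose value is within the scatter of it, while compound 3 lies beyond the scatter. For the measured compounds named here, the one single-place step measured so far, a 1.3-fold higher number from compound 1 to compound 2 (0.13 log units; within the scatter), stayed within the scatter.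

Compound 4 `O=C(O)c1ccc(Cn2nc(-c3cccnc3)c3ccccc3c2=O)cc1` has not yet been measured. It differs from compound 2 in one place: 4-carboxyphenyl in place of 3-chlorophenyl on a saturated chain carbon bound to an aromatic nitrogen. Going by the values given here, no measured step bears directly on this change, since the step from compound 1 to compound 2 exchanged an isopropyl for a 3-chlorobenzyl rather than altering the substituent on the phenyl ring. Compound 4 is therefore expected to remain close to compound 2, with an estimated step of a 1.2-fold higher number from compound 2 to compound 4 (0.08 log units; within the scatter) in this assay. For compound 4 the estimated value in this assay is 5000 nM, expected to fall between 1500 nM and 17000 nM.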

Compound 4, half-maximal inhibitory concentration: 17000 nM
The estimate for compound 4 lay 3.4-fold (0.53 log units) below the measured number, and the stated range covers the measured number.
By their numbers in this assay, from the lowest: compounds 1 and 2 (each within the scatter of the next); then compounds 3 and 4 (each within the scatter of the next).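

In this assay, 4-carboxyphenyl in place of 3-chlorophenyl on the saturated chain carbon bound to an aromatic nitrogen gave a 4.1-fold higher number from compound 2 to compound 4 (0.61 log units; beyond the scatter) and so moved the number beyond the scatter. For the compounds shown here, the earlier exchange at this position, a 1.3-fold higher number from compound 1 to compound 2 (0.13 log units; within the scatter), stayed within the scatter, so compound 4 is the first sign that the number responds to what this position carries, here to a change on the phenyl ring itself. No evidence is available on why the number rose.

The compounds shown do not separate the gain of the carboxylic acid from the loss of the chlorine, and an unsubstituted benzyl group in the same place would speak to that. On these data alone, whether a methyl ester, a primary amide or an amine on that phenyl ring would keep the number near that of compound 2 also remains open.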